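Same methyl, two cores: what the second step may show

A few compounds are considered here, and "the series" means these few. Any claim that something is new, unique, unknown or untested is made for them only; others in the source may bear on it.

Measured in a functional assay on K562 cells (Homo sapiens) for antiproliferative activity, read by MTT assay, with a stated time of 72 h; a lower number here means a stronger inhibitor, a higher number a weaker inhibitor:

compound 1 `O=C1NC(=S)S/C1=C\C1=Cc2cc(Br)ccc2OC1` gives 33700 nM
compound 2 `O=C1NC(=O)/C(=C/C2=Cc3cc(Br)ccc3OC2)N1` gives 79300 nM
compound 3 `CC1Oc2ccc(Br)cc2C=C1/C=C1\SC(=S)NC1=O` gives 31600 nM

Compound 3 differs from compound 1 in a single place, (methyl in place of hydrogen on a saturated ring carbon). In this assay this change made a step of a 1.1-fold lower number from compound 1 to compound 3 (0.03 log units; within the scatter), so the two compounds give numbers that cannot be told apart with confidence.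

Compound 2 carries a different core from compound 1; how the two cores differ is not broken down here. The values show that compound 2 gives a higher number than either compound 1 or compound 3, and both of those gaps lie beyond the usual scatter.

Compound 4 `CC1Oc2ccc(Br)cc2C=C1/C=C1\NC(=O)NC1=O` has not yet been measured. It stands to compound 2 as compound 3 stands to compound 1: it differs by methyl in place of hydrogen on a saturated ring carbon, and the place of the change is described in the same words for both pairs, so this is the same change made on the second core.

Because the earlier step of a 1.1-fold lower number from compound 1 to compound 3 (0.03 log units; within the scatter) was small, the step from compound 2 to compound 4 in this assay is expected to be small as well, a 1.1-fold lower number from compound 2 to compound 4 (0.04 log units; within the scatter). That expectation rests on a single measured pair and on nothing else. Compound 4 is therefore estimated at 72000 nM, with a likely range from 35000 nM to 150000 nM.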

Compound 4, half-maximal inhibitory concentration: 10600 nM
Compound 4: middle estimate off by 6.8-fold (0.83 log units), on the high side; measured number outside the range, below it.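

In this assay, among the compounds shown here, the same methyl in place of hydrogen on a saturated ring carbon gave a 7.5-fold lower number from compound 2 to compound 4 (0.87 log units; beyond the scatter) on the second core, whereas on the core of compound 1 it gave a 1.1-fold lower number from compound 1 to compound 3 (0.03 log units; within the scatter) and no step that could be told from the scatter. The size of this step therefore did not carry from one core to the other, and the small earlier step was no guide to the later one: the same change on two cores in this assay, a 1.1-fold lower number (0.03 log units; within the scatter) from compound 1 to compound 3 and a 7.5-fold lower number (0.87 log units; beyond the scatter) from compound 2 to compound 4, 7.0-fold (0.85 log units) apart, beyond the scatter of two such steps. This shows that, within these two pairs, the result of the change depends on the core that carries it, but it does not show why the two cores part, and two pairs cannot say which of them would be the more typical on a further core.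

The compounds shown leave open whether the larger step belongs to methyl alone or would also appear with an ethyl group, a longer chain or an amine on the same saturated ring carbon. They also leave open whether any such group would produce a clear step on the core of compound 1, where methyl produced none that could be told from the scatter.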